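The source may report more compounds than this note shows. Statements on the series, on what has been measured and on what is new or still open speak of the compounds shown alone.

Measured so far, in a functional assay on SK-MEL-2 cells (Homo sapiens) for antiproliferative activity; a lower number here means that less compound is needed, a higher number that more compound is needed for the effect:
- compound 1 `c1ccc(-c2cc(-c3cccs3)nc(-c3cccs3)c2)nc1` gives 118000 nM
- compound 2 `c1coc(-c2cc(-c3cccs3)nc(-c3cccs3)c2)c1` gives 118000 nM

Compound 2 stands level with compound 1 at the digits shown: the step of no change at the digits printed from compound 1 to compound 2 (within the scatter) lay within the scatter, so the two values show no difference that can be read as a change.

Compound 3 `c1csc(-c2cc(-c3cccs3)nc(-c3cccs3)c2)c1` has not yet been measured. It differs from compound 2 in one place: thiophen-2-yl in place of furan-2-yl on an aromatic carbon. Going by the values given here, the only measured step that bears on this change is the one from compound 1 to compound 2, in which one five-membered aromatic ring with one hetero atom took the place of a six-membered aromatic ring with one nitrogen at the same carbon, and no change at the digits printed from compound 1 to compound 2 (within the scatter). Swapping one five-membered aromatic ring with one hetero atom for another at that carbon is therefore expected to give no change at the digits printed from compound 2 to compound 3 (within the scatter) in this assay, no shift beyond the scatter in either direction. Compound 3 is accordingly expected to give 118000 nM, with a range from 59000 nM to 236000 nM.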

Compound 3, half-maximal effective concentration: 118000 nM
Estimate against measurement, compound 3: no gap at the digits printed; measured number inside the range.
By their numbers in this assay, from the lowest: compounds 1, 2 and 3 (each within the scatter of the next).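

In this assay the step from furan-2-yl to thiophen-2-yl, with sulfur in place of oxygen in the five-membered ring opposite the ring nitrogen, gives no change at the digits printed from compound 2 to compound 3 (within the scatter) and so shows that this exchange within the five-membered rings leaves no readable difference. The step from pyridin-2-yl gives no change at the digits printed from compound 1 to compound 3 (within the scatter) and thus extends the earlier flat result to a third aromatic ring at this carbon, so that pyridin-2-yl, furan-2-yl and thiophen-2-yl cannot be told apart here. Nothing measured is available to explain this sameness.

On these data alone, all three groups at this carbon are aromatic rings, so it remains open whether an amine, a carboxylic acid or a longer alkyl chain there would move the number. As far as these compounds go, the two other thiophen-2-yl groups stay the same throughout, and what a change at those places would do also remains open.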